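The source may report more compounds than this note shows. Statements on the series, on what has been measured and on what is new or still open speak of the compounds shown alone.

Compound 1 `Cc1cc(C)c(CNC(=O)c2cccc(OC(C)C)c2Cl)c(=O)[nH]1` is the weakest of the three compounds measured in an assay on Sf9 cells for inhibition of histone-lysine N-methyltransferase EZH2 (Homo sapiens), read by scintillation counting, with a stated time of 60 min, in the presence of a further agent that is not named here; a lower number here means a stronger inhibitor, a higher number a weaker inhibitor: compound 1 gives 1300 nM. Its two companions carry the same shared core but a ring-fused amide in place of the open one. Compound 2 `Cc1cc(C)c(CN2CCc3c(C)cc(O[C@@H]4CCOC4)c(Cl)c3C2=O)c(=O)[nH]1` gives 18 nM, and compound 3 `Cc1cc(C)c(CN2CCc3c(Cl)cc(-c4c(C)n[nH]c4C)c(Cl)c3C2=O)c(=O)[nH]1` gives 16 nM; both stand far below compound 1, well beyond the scatter, while the two of them sit within the scatter of each other.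

Compound 4 `Cc1cc(C)c(CNC(=O)c2cccc(OC(C)C)c2C)c(=O)[nH]1` differs from compound 1 in one place only: methyl in place of chloro on an aromatic carbon. The change sits on the aromatic carbon ortho to the isopropoxy group, and the group entering is of the same size as the one leaving. Going by the values given here, no measured pair shows the effect of swapping these two groups on this ring, so the step can only be estimated. The step from compound 1 to compound 4 is expected to be small, likely within the scatter, with no clear direction: a 1.2-fold higher number from compound 1 to compound 4 (0.06 log units; within the scatter). Compound 4 is therefore expected to give about 1500 nM in this assay, between 600 nM and 4000 nM.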

Compound 4, half-maximal inhibitory concentration: 1400 nM
Compound 4: middle estimate off by 1.1-fold (0.03 log units), on the high side; the range from low to high includes it.
By their numbers in this assay, from the lowest: compounds 3 and 2 (each within the scatter of the next); then compounds 1 and 4 (each within the scatter of the next).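

Going by these compounds alone, the exchange of chloro for methyl on an aromatic carbon ortho to an isopropoxy group gives the first direct reading at this position, and in this assay the two groups cannot be told apart (a 1.1-fold higher number from compound 1 to compound 4 (0.03 log units; within the scatter)). On the open amide, this position therefore accepts either group without a change beyond the scatter, although this rests on a single pair. Nothing available here explains why the two groups read alike.

On these data alone, whether a methoxy group, a fluoro group or a longer chain such as ethyl at this position would give the same reading remains open. As far as these compounds go, it is also open whether the exchange of chloro for methyl at this position would read the same way on the ring-fused amide of compound 2 or compound 3.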